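Hydroxy in Place of Methylsulfonyl on a Coumarin Amide

The source may hold more compounds than are shown below. What is called first, only, known or untested is meant among the compounds shown, and "the series" means these compounds.

Among the compounds with values here, compound 2 `CS(=O)(=O)c1ccc(NC(=O)c2cc3ccccc3oc2=O)cc1` stands lowest of the two numbers so far in an in vitro assay on BTI-TN-5B1-4 cells for inhibition of Amine oxidase [flavin-containing] B (Homo sapiens), read by fluorescence; on this read-out higher numbers stand for weaker inhibition and lower numbers for stronger inhibition: compound 2 gives 1.4 nM. Its nearest neighbour, compound 1 `CCc1ccc(NC(=O)c2cc3ccccc3oc2=O)cc1`, gives 890 nM in this assay. Within the data shown here, the one measured step, a 640-fold lower number from compound 1 to compound 2 (2.80 log units; beyond the scatter), shows how much the group on that aromatic carbon can move the number. Compound 3 `O=C(Nc1ccc(O)cc1)c1cc2ccccc2oc1=O` differs from compound 2 by hydroxy in place of methylsulfonyl on an aromatic carbon. Among the measured compounds shown here, no measured step covers a hydroxy at this place, so the change is judged only against the ethyl-to-methylsulfonyl step of compound 1 to compound 2. Since that step was large, a change away from methylsulfonyl is expected to raise the number, though a hydroxy need not fall back all the way to the ethyl value. Compound 3 is therefore expected to give about 40 nM in this assay, between 4 nM and 400 nM, which would be a step of a 29-fold higher number from compound 2 to compound 3 (1.46 log units; beyond the scatter).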

Compound 3, half-maximal inhibitory concentration: 800 nM
Beside the measured number, compound 3's estimate is 20-fold (1.30 log units) below it; the whole stated range lies below it.
By their numbers in this assay, from the lowest: compound 2; then compounds 3 and 1 (each within the scatter of the next).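

In this assay, hydroxy in place of methylsulfonyl gives a 570-fold higher number from compound 2 to compound 3 (2.76 log units; beyond the scatter) as a large step, so a second group at this aromatic carbon, and not ethyl alone, loses the low number of compound 2. Hydroxy in place of ethyl gives a 1.1-fold lower number from compound 1 to compound 3 (0.05 log units; within the scatter) and thus leaves these two groups unseparated at this place, and among the three compounds only methylsulfonyl goes with a low number. Nothing given here bears on what lies behind these steps.

On these data alone, whether a sulfonamide, a nitrile or a carboxylic acid at this carbon would stay close to compound 2 or fall in with compounds 1 and 3 remains open. Also open, as far as these compounds go, is how methylsulfonyl would fare on another carbon of the same ring.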